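The compounds below may be only part of what the source reports. "The series", "measured", "known", "first", "only" and "open" are said of these compounds alone.

In a physicochemical assay for solubility, with a stated time of 24 h, tested at 30 mg/mL (a lower number here means a less soluble compound, a higher number a more soluble compound), compound 1 `O=C(CCCCCCNc1c(Nc2ccccc2)c(=O)c1=O)NO` gives 1800000 nM and compound 2 `O=C(CCCCCNc1c(Nc2ccccc2)c(=O)c1=O)NO` gives 2200000 nM. Within the data shown here, compound 2 therefore has no real separation from the only other measured compound: the record shows a 1.2-fold higher number from compound 1 to compound 2 (0.09 log units; within the scatter), with hydroxycarbamoyl in place of (hydroxycarbamoyl)methyl on a saturated chain carbon. Compound 3 `O=C(CCCCCNc1c(NCc2ccccc2)c(=O)c1=O)NO` keeps the chain of compound 2 and differs from it by benzyl in place of phenyl on a nitrogen on an aromatic ring, or anilino to benzylamino. Among the measured compounds shown here, the one measured step lies elsewhere in the molecule, so it bears on this change only indirectly, and no measured pair tests this place. For the measured compounds named here, with only that small step, a 1.2-fold higher number from compound 1 to compound 2 (0.09 log units; within the scatter), as a guide, no change beyond the scatter is expected in this assay, and the estimated step is a 1.1-fold lower number from compound 2 to compound 3 (0.04 log units; within the scatter). For compound 3 the expected value is 2000000 nM, with an estimated range of 800000 nM to 4500000 nM.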

Compound 3, solubility: 5700000 nM
For compound 3 the middle estimate is 2.9-fold (0.45 log units) below the measured one, outside the stated range (above it).
By their numbers in this assay, from the lowest: compounds 1 and 2 (each within the scatter of the next); then compound 3.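

In this assay, among these compounds, this nitrogen is the first place where a single change moves the number beyond the scatter: benzyl in place of phenyl gives a 2.6-fold higher number from compound 2 to compound 3 (0.41 log units; beyond the scatter) on the same chain and core. The chain step, a 1.2-fold higher number from compound 1 to compound 2 (0.09 log units; within the scatter) and thus within the scatter, gave no sign of this, so the two measured places do not behave alike here. Both groups carry one six-membered aromatic ring of carbon only, yet anilino to benzylamino is enough to produce this modest step, and no measurement at hand accounts for it.

As far as these compounds go, the benzyl group appears only on the chain of compound 2, so whether the step holds on the chain of compound 1 stays open. Also open, from the compounds shown here alone, is what a phenethyl group on this nitrogen, or an amine or carboxylic acid on the benzyl ring, would give.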